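One Double Bond Flipped in a Polyene Amide

The source may hold more compounds than are shown below. What is called first, only, known or untested is meant among the compounds shown, and "the series" means these compounds.

Of the compounds shown here, two have been measured in a functional assay on cells (Platelet, Oryctolagus cuniculus) for inhibition, read by turbidimetry, with a stated time of 3 min, tested at 5 ug/mL; a lower number here means a stronger effect, a higher number a weaker effect of the compound at the concentration tested. Compound 1, `CC/C=C/C/C=C\CC/C=C/C=C/C(=O)NCC(C)(C)O`, is a polyunsaturated fatty acid amide bearing a hydroxylated side chain; in this assay compound 1 gives 46.2%, the lowest of the two numbers. Compound 2, `COc1ccc(C2=C(OC(C)=O)Cc3c(OC(C)=O)cc(OC)c(OC)c3O2)cc1`, is built on a different core and in this assay compound 2 gives 51.1%, within the scatter of compound 1, so no order between the two can be claimed.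

Compound 3, `CC/C=C\C/C=C\CC/C=C/C=C/C(=O)NCC(C)(C)O`, has not yet been measured. Compound 3 differs from compound 1 as follows: the two compounds have the same atoms and bonds and differ only in configuration as drawn: 1 of 4 stereo elements differ; a double bond is drawn E in compound 1 and Z in compound 3. Going by the values given here, with no step between measured compounds available, the size of the change from compound 1 to compound 3 cannot be anchored; since only configuration is altered, a step no larger than the scatter is expected, in no firm direction. The value of compound 3 in this assay is therefore estimated at 50%, within 33% to 68%, corresponding to an expected step of a number 3.8 percentage points higher from compound 1 to compound 3 (within the scatter).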

Compound 3, a percentage reported as activity, at one concentration (the size of the read-out at that concentration, not a potency): 46.2%
Compound 3: the middle estimate sits 3.8 percentage points above what was measured; low and high end bracket the measured number.
By their numbers in this assay, from the lowest: compounds 1, 3 and 2 (each within the scatter of the next).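

Going by these compounds alone, compound 1 and compound 3 provide the first comparison in this set that isolates a single place, and the earlier values could not do this because compound 1 and compound 2 are built differently. In this assay, the step from E to Z at this double bond is no change at the digits printed from compound 1 to compound 3 (within the scatter), so the read-out at this one concentration gives no sign that the configuration at this position matters. The comparison is a clean one, with only one structural difference to weigh: the fact that compounds 1 and 3 differ only in the configuration as drawn.

The compounds shown leave open whether the other double bonds tolerate the same switch, and whether a difference would appear at other concentrations. They also leave open how the read-out responds when the hydroxylated amide side chain gives way to a carboxylic acid or an amine, or when the fatty chain is a longer chain.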